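Cyclohexyl in Place of a Halogenated Phenyl

The compounds below may be only part of what the source reports. "The series", "measured", "known", "first", "only" and "open" are said of these compounds alone.

Compound 1 `CN(Cc1cc(-c2ccccc2Cl)no1)C(=O)C1CCNCC1` — 41%
Compound 2 `Fc1cccc(-c2cc(-c3cnn(C4CCNCC4)c3)on2)c1Cl` — 47%

In an assay on a protein complex for positive allosteric modulation of Neuronal acetylcholine receptor; alpha4/beta2 (Homo sapiens) (on this read-out higher numbers stand for larger maximal responses and lower numbers for smaller maximal responses), compound 1 gives 41%, and compound 2 gives 47%. Among the compounds with values here, compound 2 carries the higher of the two numbers, yet its only neighbour, compound 1, sits within the scatter of it, so the two cannot be ranked. Compound 3 `c1nn(C2CCNCC2)cc1-c1cc(C2CCCCC2)no1` has not yet been measured in this assay. It differs from compound 2 in cyclohexyl in place of 2-chloro-3-fluorophenyl on an aromatic carbon. Within the data shown here, no step between measured compounds is available to guide the size of this change, since both measured compounds keep a halogenated phenyl on the shared core. Compound 3 is therefore expected to give 35%, with a range from 15% to 55%. The expected step, a number 12 percentage points lower from compound 2 to compound 3 (beyond the scatter), is estimated to be a modest decrease, near the edge of the scatter.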

Compound 3, largest response reached (reported as efficacy), in percent of the reference or control that the assay uses: 16%
The estimate for compound 3 lay 19 percentage points above the measured number; the measured number falls inside the stated range.
By their numbers in this assay, from the lowest: compound 3; then compounds 1 and 2 (each within the scatter of the next).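

Within the data shown here, the step of a number 31 percentage points lower from compound 2 to compound 3 (beyond the scatter) in this assay is the first reading at this position, on an aromatic carbon next to the ring nitrogen. Compounds 1 and 2 both keep a halogenated phenyl there, so they could not show that the maximal response depends on this group; here, cyclohexyl in place of 2-chloro-3-fluorophenyl lowers it by a large step. No evidence at hand bears on why the response falls.

The compounds shown leave open whether the response follows the aromatic ring itself or its chlorine and fluorine, a question that unsubstituted phenyl at this place would separate. Also open, as far as these compounds go, is how a ring with nitrogen, such as pyridyl, or a small alkyl such as methyl would read here.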